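Replacing the methoxyphenyl of compound 2 with furan-3-yl

The source may report more compounds than this note shows. Statements on the series, on what has been measured and on what is new or still open speak of the compounds shown alone.

Compound 2 `COc1ccccc1/C=C1/C(C)=C(CC(=O)O)c2cc(F)ccc21` is the point of departure. In a functional assay on MDCK cells (Canis lupus familiaris) for antiproliferative activity (a lower number here means a stronger inhibitor, a higher number a weaker inhibitor), compound 2 gives 360000 nM, the highest of the two single numbers in the set so far. Among the compounds with values here, its nearest neighbour is compound 1 `COc1ccc(/C=C2/C(C)=C(CC(=O)O)c3cc(F)ccc32)cc1`, which gives 310000 nM; the step of a 1.2-fold higher number from compound 1 to compound 2 (0.06 log units; within the scatter) is the only measured step in this assay. The third member, compound 3 `CC1=C(CC(=O)O)c2cc(F)ccc2/C1=C\c1ccc(CO)o1`, has been run repeatedly and gives 130000 nM; 120000 nM (2 entries); these repeats, (the several entries of compound 3 in this assay, 130000 nM; 120000 nM (2 entries)), show how closely this assay reproduces a result, and they sit lower than the number for compound 2.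

Compound 4 `CC1=C(CC(=O)O)c2cc(F)ccc2/C1=C\c1ccoc1` differs from compound 2 in one place: furan-3-yl in place of 2-methoxyphenyl on a double-bonded chain carbon bound to a double-bonded ring carbon. Within the data shown here, no measured step swaps the six-membered aromatic ring for a five-membered one; the only step on record, a 1.2-fold higher number from compound 1 to compound 2 (0.06 log units; within the scatter), moved a methoxy group around the phenyl ring and stayed within the scatter. Among the measured compounds shown here, with no closer precedent, a step of modest size is expected in this assay, if anything toward a lower number, and not necessarily beyond the scatter. The step expected is a 1.8-fold lower number from compound 2 to compound 4 (0.26 log units; within the scatter). For compound 4 the estimated value is 200000 nM, in a range from 70000 nM to 600000 nM.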

Compound 4, half-maximal inhibitory concentration: 50000 nM
Compound 4: the middle estimate sits 4.0-fold (0.60 log units) above what was measured, and the stated range ends above it.
By their numbers in this assay, from the lowest: compound 4; then compounds 1 and 2 (each within the scatter of the next).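

Within the data shown here, at the double-bonded chain carbon bound to a double-bonded ring carbon, the earlier compounds showed only a methoxy group moved around the phenyl ring, whereas exchanging the ring itself registers clearly in this assay: furan-3-yl in place of 2-methoxyphenyl gives a 7.2-fold lower number from compound 2 to compound 4 (0.86 log units; beyond the scatter), and furan-3-yl in place of 4-methoxyphenyl gives a 6.2-fold lower number from compound 1 to compound 4 (0.79 log units; beyond the scatter). This position therefore responds to which ring it carries, and both methoxyphenyl compounds, which lie within the scatter of each other, move in the same direction when furan-3-yl enters. These steps can be set against how closely repeated entries agree in this assay: the several entries of compound 3 in this assay, 130000 nM; 120000 nM (2 entries).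

The change alters ring size, brings in a ring hetero atom, removes the methoxy group and lowers the heavy-atom count all at once, so the compounds shown cannot assign the step to any one of these differences. An unsubstituted phenyl, a thiophene or a furan-2-yl at this place would begin to separate them, and a pyridine or an amine on the ring would test how far the trend extends beyond these ring types.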